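A few compounds are considered here, and "the series" means these few. Any claim that something is new, unique, unknown or untested is made for them only; others in the source may bear on it.

Two compounds share a core carrying a basic side chain and an aryl amino group. Compound 1 `CC(C)c1ccc(Nc2ccc3c(OCCCN4CCN(C)CC4)cccc3n2)cc1` carries a 4-isopropylphenyl group and in a functional assay on UO-31 cells (Homo sapiens) for inhibition, read by sulforhodamine B assay, with a stated time of 48 h (on this read-out higher numbers stand for weaker inhibition of growth and lower numbers for stronger inhibition of growth), compound 1 gives 12900 nM. Within the data shown here, compound 2 `CN1CCN(CCCOc2cccc3nc(Nc4ccc(F)c(F)c4)ccc23)CC1` carries a 3,4-difluorophenyl group instead, and in this assay compound 2 gives 4340 nM, the lowest of the two numbers so far; the only measured step, a 3.0-fold lower number from compound 1 to compound 2 (0.47 log units; beyond the scatter), separates them. Compound 3 `CN1CCN(CCCOc2cccc3nc(Nc4cccc(Cl)c4)ccc23)CC1` differs from compound 2 by 3-chlorophenyl in place of 3,4-difluorophenyl on a nitrogen on an aromatic ring. Among the measured compounds shown here, the measured step replaced a larger alkyl-bearing phenyl with a halogenated one, whereas the step to compound 3 exchanges one halogenated phenyl for another, so no step of the same kind has been measured and the one measured step offers only a weak guide. For compound 3 in this assay the expected change is a 1.2-fold higher number from compound 2 to compound 3 (0.06 log units; within the scatter), within the usual scatter, and the estimate is 5000 nM with a range from 2000 nM to 12500 nM.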

Compound 3, concentration for 50% growth inhibition: 1840 nM
The estimate for compound 3 lay 2.7-fold (0.43 log units) above the measured number; measured number below the stated range.
By their numbers in this assay, from the lowest: compound 3; then compound 2; then compound 1.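

Exchanging one halogen-bearing phenyl for another still moves the number: 3-chlorophenyl in place of 3,4-difluorophenyl gives a 2.4-fold lower number from compound 2 to compound 3 (0.37 log units; beyond the scatter) in this assay and shows that this position on the nitrogen responds to more than the earlier swap of an alkyl-bearing phenyl for a halogen-bearing one. Set against the 4-isopropylphenyl group, the 3-chlorophenyl group gives a 7.0-fold lower number from compound 1 to compound 3 (0.85 log units; beyond the scatter) and places compound 3 lowest of the three numbers so far. No measurement at hand explains why these groups differ.

The step changes both the kind of halogen and the number of halogen atoms on the ring, so these compounds cannot separate the two. Where a plain phenyl, or a phenyl bearing bromine or a methoxy group, would fall in this order remains open.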